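This account rests on a few compounds, and the source may have more. Where it says the series, first, only, none or still open, it means among the compounds named here.

Measured so far in an assay on CHO cells for displacement of a labelled ligand from prostaglandin D2 receptor 2 (Homo sapiens), read by scintillation counting; on this read-out lower numbers stand for stronger inhibition and higher numbers for weaker inhibition:
Compound 1, `Cc1ccc(S(=O)(=O)Cc2ccccc2)cc1C#Cc1cc(Cl)ccc1OCC(=O)O`: 5 nM
Compound 3, `CS(=O)(=O)c1cccc(C#Cc2cc(Cl)ccc2OCC(=O)O)c1`: 15 nM
Compound 2, `O=C(O)COc1ccc(Cl)cc1C#Cc1cc(CO)ccc1F`: 73 nM

Compound 1 holds the lowest number of the three in this assay; compound 3 sits higher and compound 2 higher still, both gaps beyond the usual scatter. Compound 4, `CCN(CC)S(=O)(=O)c1ccc(C)c(C#Cc2cc(Cl)ccc2OCC(=O)O)c1`, has not been measured. Relative to compound 1 the change is diethylamino in place of benzyl on a sulfonyl sulfur, which cut one bond further out reads benzylsulfonyl to diethylsulfamoyl. Among the compounds with values here, no single-change step of this kind has been measured, so the expectation rests on compound 1 alone. The expected step is a 2.0-fold higher number from compound 1 to compound 4 (0.30 log units; within the scatter), a modest move toward a higher number, close to the edge of the scatter. Compound 4 is thus estimated at 10 nM, with a range from 3 nM to 35 nM.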

Compound 4, inhibition constant: 3.4 nM
The estimate for compound 4 lay 2.9-fold (0.47 log units) above the measured number; the measured number falls inside the stated range.
By their numbers in this assay, from the lowest: compounds 4 and 1 (each within the scatter of the next); then compound 3; then compound 2.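

Setting diethylamino in place of benzyl on a sulfonyl sulfur gives a 1.5-fold lower number from compound 1 to compound 4 (0.17 log units; within the scatter) in this assay. The two compounds cannot be told apart here, so a group with no ring and with a nitrogen bonded to the sulfonyl sulfur can stand in place of benzyl on this core. No data at hand account for this result.

On these data alone, whether the same holds for other groups on this sulfur, such as dimethylamino or morpholine, remains open. A single step also cannot show whether the result extends to other cores.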